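Ring Stereocentre Flip and Clearance in Rat Microsomes

A few compounds are considered here, and "the series" means these few. Any claim that something is new, unique, unknown or untested is made for them only; others in the source may bear on it.

Compound 1, `COc1cc(N2CCN(C(=O)Cn3cnc4cccc(C(F)(F)F)c43)CC2)ccc1-c1cnc(C)o1`: 7 mL.min-1.g-1
Compound 2, `COc1cc(N2CCN(C(=O)CN3Cc4ccccc4C3)CC2)ccc1-c1cnc(C)o1`: 42 mL.min-1.g-1
Compound 3, `COc1cc(N2CCN(C(=O)N[C@@H](C)c3cccc4ccccc34)C[C@@H]2C)ccc1-c1cnc(C)o1`: 150 mL.min-1.g-1

In an ADME assay on microsomes from liver (Rattus norvegicus) for metabolic stability, read by LC-MS (a lower number here means slower removal, a higher number faster removal of the compound), compound 3 stands highest of the three numbers. Its nearest neighbour is compound 2, whose number is lower beyond the scatter, and the furthest is compound 1, lower still and well beyond the scatter. Compound 4, `COc1cc(N2CCN(C(=O)N[C@@H](C)c3cccc4ccccc34)C[C@H]2C)ccc1-c1cnc(C)o1`, is not yet measured. It differs from compound 3 as follows: the two compounds have the same atoms and bonds and differ only in configuration as drawn: 1 of 2 stereo elements differ; a stereocentre at a saturated ring carbon is drawn S in compound 3 and R in compound 4. Among the compounds with values here, nothing among the measured compounds shows how this configuration change behaves, so the expected step in this assay from compound 3 to compound 4 is a 1.2-fold lower number from compound 3 to compound 4 (0.06 log units; within the scatter), within the scatter and in no firm direction. For compound 4 the estimate in this assay is 130 mL.min-1.g-1, with a range from 50 mL.min-1.g-1 to 320 mL.min-1.g-1.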

Compound 4, intrinsic clearance in microsomes: 150 mL.min-1.g-1
For compound 4 the middle estimate is 1.2-fold (0.06 log units) below the measured one; low and high end bracket the measured number.
By their numbers in this assay, from the lowest: compound 1; then compound 2; then compounds 3 and 4 (each within the scatter of the next).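

In this assay, inverting the stereocentre at a saturated ring carbon gives no change at the digits printed from compound 3 to compound 4 (within the scatter). At this position, then, the drawn configuration does not separate the two compounds in this read-out. This is the first measured pair to isolate a single change, and that change is purely one of configuration: the fact that compounds 3 and 4 differ only in the configuration as drawn

Still open, as far as these compounds go, is whether an ethyl or hydroxyl group at that saturated ring carbon would give a different number. Also open, from the compounds shown here alone, is whether inverting the other stereo element would leave the number equally undisturbed.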